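This account rests on a few compounds, and the source may have more. Where it says the series, first, only, none or still open, it means among the compounds named here.

Compound 1, `O=C(Nc1cccc(Nc2ncc(F)c(Nc3ccc(F)cc3)n2)c1)c1cnccn1`: 20100 nM
Compound 2, `O=C(Nc1cccc(Nc2ncc(F)c(Nc3ccc(F)cc3)n2)c1)c1cccc([N+](=O)[O-])c1`: 11400 nM

Both compounds were tested in a functional assay on KBVIN cells (Homo sapiens) for antiproliferative activity, read by sulforhodamine B assay, with a stated time of 3 days; a lower number here means a stronger inhibitor of growth, a higher number a weaker inhibitor of growth. In this assay compound 1 gives 20100 nM and compound 2 gives 11400 nM. Within the data shown here, compound 1 stands at the top of these two numbers, yet its only neighbour lies close: the step is a 1.8-fold lower number from compound 1 to compound 2 (0.25 log units; within the scatter), so the two compounds cannot be told apart on this evidence. That step put 3-nitrophenyl in place of pyrazin-2-yl on a carbonyl carbon.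

Compound 3, `Cn1ccnc1NC(=O)c1cccc(Nc2ncc(F)c(Nc3ccc(F)cc3)n2)c1`, has not yet been measured. It differs from compound 1 in one place: (1-methyl-1H-imidazol-2-yl)carbamoyl in place of ((pyrazin-2-yl)carbonyl)amino on an aromatic carbon. A five-membered aromatic ring with two hetero atoms thus stands where a six-membered one stood. Among the measured compounds shown here, no measured step touches a change of this kind; the single step available, a 1.8-fold lower number from compound 1 to compound 2 (0.25 log units; within the scatter), kept the same linking group and changed only the ring on the carbonyl carbon, and it stayed within the scatter. There is therefore nothing to point in either direction, and a step within the scatter is expected, with a wide range. Compound 3 is expected to give 20000 nM (5000 nM to 80000 nM), which corresponds to a 1.0-fold lower number from compound 1 to compound 3 (0.00 log units; within the scatter).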

Compound 3, concentration for 50% growth inhibition: 13100 nM
Estimate against measurement, compound 3: 1.5-fold (0.18 log units) above; the measured number falls inside the stated range.
By their numbers in this assay, from the lowest: compounds 2, 3 and 1 (each within the scatter of the next).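

In this assay the new group gives a 1.5-fold lower number from compound 1 to compound 3 (0.19 log units; within the scatter) and so stays within the scatter, even though this change reaches further than the earlier one. The step from compound 1 to compound 2 altered only the ring on the carbonyl carbon, whereas here the amide link is turned around, so that its carbonyl carbon now sits on the aromatic carbon, and a five-membered ring replaces a six-membered one, with the counts of heavy atoms, donors and acceptors the same in both groups. At this position, then, changing the direction of the link and the size of the ring together produces no difference that can be read in this assay, and no other measurement bears on the result.

On these data alone, with both changes made at once, the contribution of each remains unknown: the turned-around link might carry a pyrazin-2-yl ring, or the original link a 1-methyl-1H-imidazol-2-yl ring. Also open, as far as these compounds go, is whether something other than an aromatic ring at this place, such as a morpholine, a simple amine or a carboxylic acid, would give a step beyond the scatter.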